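Stretching a methoxy to an ethoxy at the assay's limit

The source may report more compounds than this note shows. Statements on the series, on what has been measured and on what is new or still open speak of the compounds shown alone.

The three measured compounds share one core and differ only in the groups on the pendant aromatic ring. Compound 1 `CC(C)Oc1nc(N)nc2ncc(-c3ccc(C#N)cc3)nc12` carries a cyano group there. In a functional assay on cells (T-cell, Homo sapiens) for inhibition (a higher number here means a weaker inhibitor, a lower number a stronger inhibitor), compound 1 gives > 10000 nM, which is a limit of the assay rather than a number. Within the data shown here, compound 2 `COc1ccc(-c2cnc3nc(N)nc(OC(C)C)c3n2)cc1OC` bears two methoxy groups and gives 400 nM in this assay, the only measured number among the three. Compound 3 `COc1ccc(-c2cnc3nc(N)nc(OC(C)C)c3n2)cc1` keeps one methoxy group. In this assay compound 3 gives > 10000 nM, again a limit and not a number, so compound 3 sits at the limit of > 10000 nM in this assay, at which 2 of the 3 values shown sit. Removing the second methoxy brought an at least 25-fold higher number from compound 2 to compound 3 (1.39 log units; beyond the scatter), whereas a step that the two limits leave unreadable from compound 1 to compound 3 cannot be sized.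

Compound 4 `CCOc1ccc(-c2cnc3nc(N)nc(OC(C)C)c3n2)cc1` differs from compound 3 by methyl in place of hydrogen on a saturated chain carbon bound to an oxygen on an aromatic ring; cut one bond further out, the change reads as methoxy to ethoxy. Among the measured compounds shown here, no measured step alters this methoxy in this way, so the step of a number no higher from compound 3 to compound 4 (the limit leaves the size open) is expected to stay within the scatter, with a strong chance that only a limit is reported again. Compound 4 is therefore estimated at 10000 nM, within 3000 nM to 30000 nM.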

Compound 4, half-maximal inhibitory concentration: 10000 nM
Beside the measured number, compound 4's estimate shows no gap at the digits printed; the range from low to high includes it.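

On the saturated chain carbon bound to an oxygen on an aromatic ring, a methyl in place of hydrogen turns methoxy into ethoxy, and in this assay compound 4 gives 10000 nM. Compound 1 and compound 3 each give only a limit: the limit of > 10000 nM in this assay, at which 2 of the 4 values shown sit. Methyl in place of hydrogen brings a number no higher from compound 3 to compound 4 (the limit leaves the size open), and ethoxy in place of cyano brings a number no higher from compound 1 to compound 4 (the limit leaves the size open). Neither step can be read, so the ethoxy group gives a reading at the very edge of the assay, but no gain over methoxy can be sized.

From the compounds shown here alone, whether a longer chain on this oxygen, such as propoxy or butoxy, would bring a clearly lower number stays open. So does the effect of an amine in place of the ethoxy group on the pendant aromatic ring.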